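Ethylamino in Place of Hydroxy on the Bicyclic Ring

A few compounds are considered here, and "the series" means these few. Any claim that something is new, unique, unknown or untested is made for them only; others in the source may bear on it.

Compound 1 `CC1CN(S(=O)(=O)C[C@]23CC[C@H](CC2=O)C3(C)C)CCN1c1ccc(C(F)(F)F)cn1`: 316 nM
Compound 2 `CC1CN(c2ccc(C(F)(F)F)cn2)CCN1S(=O)(=O)C[C@]12CC[C@H](CC1=O)C2(C)C`: 631 nM
Compound 3 `CC1(C)[C@@H]2CC[C@@]1(CS(=O)(=O)N1CCN(c3ccc(C(F)(F)F)cn3)CC1)C(O)C2`: 158 nM

Of the compounds shown here, three have been tested in a functional assay on CHO-K1 cells for antagonist activity at C-X-C chemokine receptor type 3 (Homo sapiens), read by FLIPR and calcium flux; on this read-out lower numbers stand for stronger inhibition and higher numbers for weaker inhibition. Compound 3 gives 158 nM, the lowest of the three numbers; its gap to compound 1 lies within the usual scatter, whereas its gap to compound 2 lies beyond it. Compound 4 `CCNC1C[C@H]2CC[C@]1(CS(=O)(=O)N1CCN(c3ccc(C(F)(F)F)cn3)CC1)C2(C)C` has not yet been measured. It differs from compound 3 by ethylamino in place of hydroxy on a saturated ring carbon. Among the compounds with values here, no measured pair shows the effect of such a change, so the direction is open; the step of a 1.6-fold higher number from compound 3 to compound 4 (0.20 log units; within the scatter) is expected to stay small. Compound 4 is estimated to give 250 nM in this assay, with a range from 60 nM to 1000 nM.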

Compound 4, half-maximal inhibitory concentration: 7940 nM
Estimate against measurement, compound 4: 32-fold (1.50 log units) below; measured number outside the range, above it.
By their numbers in this assay, from the lowest: compounds 3, 1 and 2 (each within the scatter of the next, the first and the last beyond it); then compound 4.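

In this assay, within the data shown here, ethylamino in place of hydroxy on this saturated ring carbon gives a 50-fold higher number from compound 3 to compound 4 (1.70 log units; beyond the scatter) and so shows that the number depends strongly on the group at this position, which the earlier compounds could not show. The change leaves the counted hydrogen-bond donor and acceptor the same, so those counts alone do not separate the two compounds. No measurement on hand offers an explanation for this step.

The compounds shown leave open whether the step follows the ethyl chain or the amine nitrogen. A plain amino group or a methoxy group on this carbon would separate the two.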